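Replacing a Biphenyl Arm with a Fluorostyryl Group

The source may hold more compounds than are shown below. What is called first, only, known or untested is meant among the compounds shown, and "the series" means these compounds.

Compound 1, `COC(=O)/C=C/c1cccc(N(Cc2ccc(-c3ccc(N(C)C)cc3)cc2)C(=O)C(C)C)c1`: 57 nM
Compound 2, `COC(=O)/C=C/c1cccc(N(Cc2ccc(-c3ccc(C(C)(C)C)cc3)cc2)C(=O)C2CCCCC2)c1`: 132 nM

Of the compounds shown here, two have been measured in an assay on isolated protein with Bile acid receptor (Homo sapiens) as the target; on this read-out higher numbers stand for an effect only at larger amounts of compound and lower numbers for an effect already at smaller amounts. Compound 2 gives 132 nM, the higher of the two numbers; its nearest neighbour, compound 1, gives 57 nM, and the gap between these two values lies beyond the usual scatter of repeated measurements. The two compounds differ in more than one place, so no single structural step accounts for that gap.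

Compound 3, `COC(=O)/C=C/c1cccc(N(Cc2ccc(/C=C/c3ccc(F)cc3)cc2)C(=O)C2CCCCC2)c1`, is not yet measured. It differs from compound 2 in one place: 2-(4-fluorophenyl)ethenyl in place of 4-(tert-butyl)phenyl on an aromatic carbon. The rest of the molecule is unchanged.

Among the measured compounds shown here, no measured pair shows this particular exchange, so the expectation rests on the two values above and on the size of the change alone. For compound 3 in this assay the estimate is 100 nM, with a range from 35 nM to 300 nM. The step of a 1.3-fold lower number from compound 2 to compound 3 (0.12 log units; within the scatter) is thus expected to be small, toward a slightly lower number but not clearly beyond the scatter.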

Compound 3, half-maximal effective concentration: 185 nM
Estimate against measurement, compound 3: 1.9-fold (0.27 log units) below; the measured number falls inside the stated range.
By their numbers in this assay, from the lowest: compound 1; then compounds 2 and 3 (each within the scatter of the next).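

In this assay, the exchange of 4-(tert-butyl)phenyl for 2-(4-fluorophenyl)ethenyl, with the rest of the molecule unchanged, gives a 1.4-fold higher number from compound 2 to compound 3 (0.15 log units; within the scatter). Among the compounds shown here, this is the first step that can be read at a single place, and it shows that this position, on an aromatic carbon para to a large group, takes either arm with no change beyond the scatter, even though the incoming arm brings a double bond outside the aromatic rings and a fluorine. No measurement here bears on why the two arms read alike.

The compounds shown leave open whether this tolerance extends to other arms at the position, such as an unsubstituted styryl group or one carrying an amine or a carboxylic acid in place of the fluorine. They also leave open how much of the gap to compound 1, which differs from compound 2 and compound 3 in more than one place, belongs to its 4-(dimethylamino)phenyl arm and how much to its different amide group, since neither change can be read alone.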